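A few compounds are considered here, and "the series" means these few. Any claim that something is new, unique, unknown or untested is made for them only; others in the source may bear on it.

Of the compounds shown here, three sharing one core have been measured in an assay on cells for activation of probable G-protein coupled receptor 34 (Mus musculus), with a stated time of 1 h; on this read-out higher numbers stand for larger maximal responses and lower numbers for smaller maximal responses. Compound 1 `N[C@@H](COP(=O)(O)OCCCOC(=O)CCc1ccccc1OCc1cccc(Oc2ccccc2)c1)C(=O)O` gives 0.48, compound 2 `N[C@@H](COP(=O)(O)OCCCOC(=O)CCc1ccccc1OCc1cccc(Cc2ccccc2)c1)C(=O)O` gives 0.077, and compound 3 `N[C@@H](COP(=O)(O)OCCCOC(=O)CCc1ccccc1OCc1cccc(OC2CCCCC2)c1)C(=O)O` gives 0.11. On these numbers compound 3 sits second of the three, close to compound 2 and well beneath compound 1. Compound 4 `Cc1ccccc1Oc1cccc(COc2ccccc2CCC(=O)OCCCOP(=O)(O)OC[C@H](N)C(=O)O)c1` differs from compound 3 in one place: 2-methylphenyl in place of cyclohexyl on an oxygen on an aromatic ring. The step bearing most directly on this change is a number 0.37 lower from compound 1 to compound 3 (beyond the scatter), which the new compound largely reverses, bringing an aromatic ring back in place of the cyclohexyl. The step a number 0.40 lower from compound 1 to compound 2 (beyond the scatter) concerns a different kind of change and so weighs less here. A large upward step, a number 0.29 higher from compound 3 to compound 4 (beyond the scatter), is therefore expected. Compound 4 is estimated at 0.4, within 0.2 to 0.55.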

Compound 4, intrinsic activity: the largest response reached, as a fraction of the reference agonist's: 0.28
Beside the measured number, compound 4's estimate is 0.12 above it, within the range that was stated.
By their numbers in this assay, from the lowest: compounds 2 and 3 (each within the scatter of the next); then compound 4; then compound 1.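

Putting an aromatic ring back on this oxygen restores part of the response, since 2-methylphenyl in place of cyclohexyl gives a number 0.17 higher from compound 3 to compound 4 (beyond the scatter), and 2-methylphenoxy in place of benzyl gives a number 0.20 higher from compound 2 to compound 4 (beyond the scatter). The added methyl is not neutral, however: methyl in place of hydrogen on an aromatic carbon gives a number 0.20 lower from compound 1 to compound 4 (beyond the scatter), so the plain phenoxy of compound 1 remains ahead of compound 4. No available measurement explains these shifts. Going by these compounds, what a fluorine or a methoxy group in place of this methyl would do remains open.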